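Series notes: the step from compound 3 to compound 4

The source may hold more compounds than are shown below. What is called first, only, known or untested is meant among the compounds shown, and "the series" means these compounds.

In a functional assay (trachea) with Cavia porcellus as the target (on this read-out higher numbers stand for weaker inhibition and lower numbers for stronger inhibition), compound 1 `O=c1c2ccccc2c(-c2cccnc2)nn1C1CCCC1` gives 2750 nM, compound 2 `CC(=O)Cn1nc(-c2cccnc2)c2ccccc2c1=O` gives 40700 nM and compound 3 `O=c1c2ccccc2c(-c2cccnc2)nn1CCSc1nccs1` gives 10500 nM. Compound 3 thus has the second highest of the three numbers, and both others lie beyond the scatter from it.

Compound 4 `NCCn1nc(-c2cccnc2)c2ccccc2c1=O` is not yet measured. It carries amino in place of (1,3-thiazol-2-yl)sulfanyl on a saturated chain carbon, two bonds along the chain from an aromatic nitrogen.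

Among the compounds with values here, no measured step makes this exact change, but all three measured steps alter the same chain. Replacing cyclopentyl gives a 3.8-fold higher number from compound 1 to compound 3 (0.58 log units; beyond the scatter) with the sulfur-linked chain and a 15-fold higher number from compound 1 to compound 2 (1.17 log units; beyond the scatter) with 2-oxopropyl. The only short ring-free chain measured is 2-oxopropyl, and it stands on the high side: a 3.9-fold lower number from compound 2 to compound 3 (0.59 log units; beyond the scatter). A modest move towards a higher number is therefore expected in this assay, estimated as a 2.4-fold higher number from compound 3 to compound 4 (0.38 log units; beyond the scatter). For compound 4 the estimated value is 25000 nM, with an expected range of 7000 nM to 90000 nM.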

Compound 4, half-maximal inhibitory concentration: > 100000 nM
Compound 4: only a limit was reported (the forecaster's own chance of this, stated with the estimate: 15%); middle value at least 4.0-fold (0.60 log units) from the limit.
By their numbers in this assay, from the lowest: compound 1; then compound 3; then compound 2. At a limit, above all of these: compound 4.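

In this assay compound 4 gives > 100000 nM, which is a limit of the assay and not a number. Amino at this place gives an at least 9.5-fold higher number from compound 3 to compound 4 (0.97 log units; beyond the scatter), the comparison with the acetyl end gives an at least 2.4-fold higher number from compound 2 to compound 4 (0.39 log units; beyond the scatter), and the comparison with the cyclopentyl group gives an at least 36-fold higher number from compound 1 to compound 4 (1.56 log units; beyond the scatter). Within the data shown here, the chain on the aromatic nitrogen therefore moves the read-out further than the earlier compounds showed, and 2-aminoethyl now stands above 2-oxopropyl, which had held the highest number.

On these data alone, the true distance of compound 4 stays open, since only its limit is available: the limit of > 100000 nM in this assay, at which 1 of the 4 values shown sits. Also open is whether the shift follows from the amine itself or from the loss of the (1,3-thiazol-2-yl)sulfanyl group, which a 2-hydroxyethyl chain, a plain ethyl chain or a longer chain ending in amino could separate.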